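The source may hold more compounds than are shown below. What is called first, only, known or untested is meant among the compounds shown, and "the series" means these compounds.

Compound 1 `CCCCCN[C@@H]1C=C[C@H](O)[C@H](O)[C@H]1O` and compound 2 `CCC(CC)CN[C@@H]1C=C[C@H](O)[C@H](O)[C@H]1O` share a core that is a ring carrying three hydroxyl groups and an amine nitrogen, and they differ only in the chain on that nitrogen. In an assay for inhibition of beta-galactosidase (Homo sapiens), read by fluorescence, with a stated time of 30 min, at pH 4.5 (a lower number here means a stronger inhibitor, a higher number a weaker inhibitor), compound 1 gives 19000 nM, and compound 2 gives 15000 nM. Compound 1 has the highest of the two numbers, and its nearest neighbour is compound 2, with a 1.3-fold lower number from compound 1 to compound 2 (0.10 log units; within the scatter), so the two cannot be told apart.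

Compound 3 `CCC(CC)N[C@@H]1C=C[C@H](O)[C@H](O)[C@H]1O` is built from the same atoms as compound 1, joined differently: pentan-3-yl in place of pentyl on an amine nitrogen. For the measured compounds named here, the one measured step that bears on this is the move from compound 1 to compound 2, which also swapped one five-carbon arrangement for another on the chain bound to the amine nitrogen and produced a 1.3-fold lower number from compound 1 to compound 2 (0.10 log units; within the scatter). On that basis, a change in this assay beyond the scatter is not expected; the step from compound 1 to compound 3 is estimated at a 1.1-fold lower number from compound 1 to compound 3 (0.05 log units; within the scatter). Compound 3 is therefore expected to give about 17000 nM in this assay, with a likely range from 7000 nM to 40000 nM.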

Compound 3, half-maximal inhibitory concentration: > 1000000 nM
Compound 3: only a limit was reported (the forecaster's own chance of this, stated with the estimate: 5%); at least 58-fold (1.76 log units) between middle value and limit.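

Replacing pentyl with pentan-3-yl on an amine nitrogen gives an at least 52-fold higher number from compound 1 to compound 3 (1.72 log units; beyond the scatter) in this assay, even though no atom is added or removed. The earlier step, a 1.3-fold lower number from compound 1 to compound 2 (0.10 log units; within the scatter), showed no such change: there, pentan-3-yl sits on a saturated chain carbon bound to an amine nitrogen, whereas in compound 3 it sits on the amine nitrogen itself, so the same five-carbon group can be accommodated in one place and not in the other. The figure for compound 3 is a limit and not a number, so the true size of the step stays unknown: the limit of > 1000000 nM in this assay, at which 1 of the 3 values shown sits.

The three compounds give no reason for this loss, and they cannot show whether it belongs to pentan-3-yl alone. From the compounds shown here alone, it remains open whether a smaller group such as isopropyl, or a ring such as cyclopentyl, on the same amine nitrogen would stay close to compound 1 or fall away as compound 3 does.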